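Iodo Out, Dimethylamino In: An Estimate for a Cell Assay

The compounds below may be only part of what the source reports. "The series", "measured", "known", "first", "only" and "open" are said of these compounds alone.

Three compounds have results in a functional assay on L1210 cells (Mus musculus) for inhibition; a higher number here means a weaker inhibitor, a lower number a stronger inhibitor. For compound 1 `O=c1cc(O)ccn1COCCO` the assay reports only a limit, > 1000 ug/mL. Compound 2 `CC(=O)OCCOCn1cnc2c(Cl)nc(Cl)nc21` gives 12 ug/mL, and compound 3 `Nc1nc2c(nc(I)n2COCCO)c(=O)[nH]1` gives 39 ug/mL, the higher of the two plain numbers, so compound 3 is the weaker inhibitor of that pair and the gap lies beyond the usual scatter. Compound 4 `CN(C)c1nc2c(=O)[nH]c(N)nc2n1COCCO` is compound 3 with a single change: dimethylamino in place of iodo on an aromatic carbon. Among the measured compounds shown here, no pair of measured compounds differs in only one place, so no measured step guides this exchange. For the measured compounds named here, with no precedent to lean on, a modest weakening of inhibition is expected, a 2.6-fold higher number from compound 3 to compound 4 (0.41 log units; beyond the scatter). Compound 4 is therefore estimated at about 100 ug/mL, within a range from 30 ug/mL to 500 ug/mL.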

Compound 4, concentration for 50% inhibition: > 500 ug/mL
Compound 4 was reported as a limit (the forecaster's own chance of this, stated with the estimate: 25%); middle value at least 5.0-fold (0.69 log units) from the limit.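

On this aromatic carbon, between two ring nitrogen atoms, exchanging iodo for dimethylamino has a large effect: in this assay there is an at least 12-fold higher number from compound 3 to compound 4 (1.10 log units; beyond the scatter). Among the compounds shown here, this is the only measured step at this position, and it links dimethylamino here to much weaker inhibition than iodo. The step is itself a minimum, as compound 4 stands only as a limit of the assay: the limit of > 500 ug/mL in this assay, at which 1 of the 4 values shown sits.

The compounds shown leave open how much weaker compound 4 truly is. They also leave open whether a plain amino group or methylamino on this carbon would keep the inhibition seen with iodo.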